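This account rests on a few compounds, and the source may have more. Where it says the series, first, only, none or still open, it means among the compounds named here.

The series rests on one core, carried by compound 1 `O=C(NC(=S)NCc1ccc(C(F)(F)F)cc1)c1ccccc1`, compound 2 `O=C(NC(=S)NCc1cccs1)c1ccccc1` and the still unmeasured compound 3 `O=C(NC(=S)NCc1ccccc1)c1ccccc1`. In an assay on isolated protein for inhibition of histone deacetylase 11 (Homo sapiens), read by fluorescence, tested at 100 uM (on this read-out higher numbers stand for more inhibition at the one concentration tested (going by the name of the read-out) and lower numbers for less inhibition), compound 1 gives "not active" (no number reported). In this assay compound 2 gives 12%, which is the only number shown in the set; the entry for compound 1 carries no number, so compound 2 has no measured neighbour to be ranked against. Compound 3 differs from compound 2 in one place: phenyl in place of thiophen-2-yl on a saturated chain carbon bound to an amide-type nitrogen. Among the compounds with values here, no step between measured compounds is available, so there is nothing that tells how much a change at this position moves the read-out. The expected step from compound 2 to compound 3 is a number 3 percentage points lower from compound 2 to compound 3 (within the scatter), which stays within the usual scatter. Compound 3 is therefore estimated at 9%, with a range from 0% to 20%.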

Compound 3, a percentage reported as inhibition, at one concentration (the size of the read-out at that concentration, not a potency): "not active" (no number reported)
Nothing numeric was reported for compound 3; no gap can be computed for the estimate.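

Within the data shown here, compound 3 carries no number in this assay, so no new step from compound 2 or compound 1 can be read. The compounds shown leave open how far a change on the saturated chain carbon bound to an amide-type nitrogen moves the inhibition. No supporting evidence bears on this result.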